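The compounds below may be only part of what the source reports. "The series", "measured", "known", "first", "only" and "open" are said of these compounds alone.

Measured compounds:
Compound 1 `O=C(OCc1ccccc1)c1cccc(=O)[nH]1` gives 69000 nM in an assay on isolated protein for inhibition of matrix metalloproteinase-9 (Homo sapiens); a lower number here means a stronger inhibitor, a higher number a weaker inhibitor.
Compound 2 `O=C(OCc1ccccc1Br)c1cccc(=O)[nH]1` gives 59000 nM.
Compound 3 `COc1cccc(COC(=O)c2cccc(S)n2)c1` gives 93000 nM.

Compound 2 shows the lowest of the three numbers, but its gap to compound 1 and its gap to compound 3 both lie within the scatter, so the three compounds are not separated. Compound 4 `O=C(OCc1ccccc1Cl)c1cccc(=O)[nH]1` differs from compound 2 by chloro in place of bromo on an aromatic carbon. Among the compounds with values here, the one measured step at this position is a 1.2-fold lower number from compound 1 to compound 2 (0.07 log units; within the scatter), which was within the scatter. Within the data shown here, no measured pair exchanges one halogen for another, so the expectation rests on that single step alone. The change from compound 2 to compound 4 is therefore expected to give a 1.1-fold higher number from compound 2 to compound 4 (0.02 log units; within the scatter), no shift beyond the scatter. In this assay compound 4 is estimated at 62000 nM, with a range from 30000 nM to 130000 nM.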

Compound 4, half-maximal inhibitory concentration: 81000 nM
The estimate for compound 4 lay 1.3-fold (0.12 log units) below the measured number; low and high end bracket the measured number.
By their numbers in this assay, from the lowest: compounds 2, 1, 4 and 3 (each within the scatter of the next).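

The exchange of one halogen for the other on this aromatic carbon gives a 1.4-fold higher number from compound 2 to compound 4 (0.14 log units; within the scatter) and so moves nothing beyond the scatter in this assay. Chloro in place of hydrogen gives a 1.2-fold higher number from compound 1 to compound 4 (0.07 log units; within the scatter) and, like bromo in place of hydrogen, stays within the scatter, so neither halogen separates from hydrogen at this position. On these data alone, whether an amine or a carboxylic acid on this carbon would shift the number beyond the scatter remains open. No evidence at hand accounts for these small differences.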